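Compound 3: propyl in place of 3-methylphenyl

A few compounds are considered here, and "the series" means these few. Any claim that something is new, unique, unknown or untested is made for them only; others in the source may bear on it.

- compound 1 `CCCn1cc(COc2cc(O)c3c(c2)O[C@H](c2ccc(OC)c(O)c2)CC3=O)nn1` gives 9670 nM
- compound 2 `COc1ccc([C@@H]2CC(=O)c3c(O)cc(OCc4cn(Cc5cccc(C)c5)nn4)cc3O2)cc1O` gives 17400 nM

In a functional assay on RAW264.7 cells (Mus musculus) for inhibition, read by Griess assay, with stated times of 2 h and 24 h (a lower number here means a stronger inhibitor, a higher number a weaker inhibitor), compound 2 stands at 17400 nM and compound 1 at 9670 nM, and the two lie within the scatter of each other. Compound 3 `CCCCn1cc(COc2cc(O)c3c(c2)O[C@H](c2ccc(OC)c(O)c2)CC3=O)nn1` has not yet been measured. Relative to compound 2 it carries propyl in place of 3-methylphenyl on a saturated chain carbon bound to an aromatic nitrogen. In words, this is propyl in place of 3-methylphenyl on a saturated chain carbon bound to an aromatic nitrogen, which also reads as 3-methylbenzyl to butyl.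

For the measured compounds named here, one measured step bears on this change: a 1.8-fold higher number from compound 1 to compound 2 (0.26 log units; within the scatter), with 3-methylphenyl in place of ethyl at that same place. That step stays within the scatter, so exchanging the aromatic group for a short chain has shown no resolved effect so far in this assay. Going by the values given here, this rests on two values only, and no butyl compound has a measurement yet. No step beyond the scatter is expected. The estimated step is a 1.6-fold lower number from compound 2 to compound 3 (0.20 log units; within the scatter). For compound 3 the expected value is 11000 nM, with an estimated range of 5000 nM to 24000 nM.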

Compound 3, half-maximal inhibitory concentration: 13900 nM
Compound 3: middle estimate off by 1.3-fold (0.10 log units), on the low side, and the stated range covers the measured number.
By their numbers in this assay, from the lowest: compounds 1, 3 and 2 (each within the scatter of the next).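

In this assay, the exchange of 3-methylphenyl for propyl on a saturated chain carbon bound to an aromatic nitrogen gives a 1.3-fold lower number from compound 2 to compound 3 (0.10 log units; within the scatter), so a direct comparison of the aromatic group with an open chain at this place also resolves no effect. The second new comparison concerns chain length alone: methyl in place of hydrogen on a saturated chain carbon, three bonds along the chain from an aromatic nitrogen, gives a 1.4-fold higher number from compound 1 to compound 3 (0.16 log units; within the scatter), again with no resolved effect. Across compound 1, compound 2 and compound 3, this place therefore tolerates both open chains and the 3-methylbenzyl group without a separable difference in this small set, and no accompanying measurement offers an explanation for these values.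

On these data alone, all three groups at this place contain carbon only, so it remains open whether an amine, a carboxylic acid or a hydroxyl group at the end of the chain would give a step beyond the scatter in this assay. A much longer chain, such as octyl, and changes to the shared core also remain untested in the compounds shown here.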